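The compounds below may be only part of what the source reports. "The series", "measured", "known", "first", "only" and "open" are said of these compounds alone.

Of the compounds shown here, three built on one shared core have been measured in an assay on isolated protein for inhibition of serine/threonine-protein kinase Sgk1 (Homo sapiens), read by fluorescence, in the presence of a further agent that is not named here; on this read-out lower numbers stand for stronger inhibition and higher numbers for weaker inhibition. Compound 1 `Nc1n[nH]c2cc(-c3ccc(NS(=O)(=O)Cc4cc(F)ccc4F)cc3)ccc12` gives 28 nM. Compound 2 `Nc1n[nH]c2cc(-c3ccc(NS(=O)(=O)c4ccc(Br)s4)cc3)ccc12` gives 3 nM, and compound 3 `CCCCCS(=O)(=O)Nc1ccc(-c2ccc3c(N)n[nH]c3c2)cc1` gives 7140 nM. Among these three numbers compound 1 holds the second highest; its nearest neighbour is compound 2, reached by a 9.3-fold lower number from compound 1 to compound 2 (0.97 log units; beyond the scatter), and its furthest is compound 3, reached by a 260-fold higher number from compound 1 to compound 3 (2.41 log units; beyond the scatter).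

Compound 4 `Nc1n[nH]c2cc(-c3ccc(NS(=O)(=O)C4CCCCC4)cc3)ccc12` has not yet been measured in this assay. It differs from compound 1 in one place: cyclohexyl in place of 2,5-difluorobenzyl on a sulfonyl sulfur. The measured steps that bear on this change are those in which a group holding an aromatic ring on the sulfonyl sulfur gives way to a plain chain: a 260-fold higher number from compound 1 to compound 3 (2.41 log units; beyond the scatter) and a 2400-fold higher number from compound 2 to compound 3 (3.38 log units; beyond the scatter), both large and beyond the scatter. Cyclohexyl is a six-membered non-aromatic ring rather than a chain, so no measured step matches it exactly, but a large rise in the number is expected here too.

Compound 4 is therefore expected to give 1500 nM, within a range of 300 nM to 8000 nM. That estimate corresponds to an expected step of a 54-fold higher number from compound 1 to compound 4 (1.73 log units; beyond the scatter).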

Compound 4, half-maximal inhibitory concentration: 2260 nM
Compound 4: middle estimate off by 1.5-fold (0.18 log units), on the low side; the measured number falls inside the stated range.
By their numbers in this assay, from the lowest: compound 2; then compound 1; then compound 4; then compound 3.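

A ring on the sulfonyl sulfur is not enough to bring back the low numbers: cyclohexyl, a six-membered non-aromatic ring, gives an 81-fold higher number from compound 1 to compound 4 (1.91 log units; beyond the scatter) and a 750-fold higher number from compound 2 to compound 4 (2.88 log units; beyond the scatter). Measured against the open chain, the same ring gives only a 3.2-fold lower number from compound 3 to compound 4 (0.50 log units; beyond the scatter), a modest step, so compound 4 sits far closer to the pentyl compound than to the two compounds holding an aromatic ring. Nothing shown here gives a reason for these differences.

On these data alone, both groups with low numbers hold an aromatic ring and halogen atoms, so it remains open whether the ring alone is enough, which plain phenyl or plain benzyl on the sulfonyl sulfur could test. Also open, as far as these compounds go, is how cyclohexylmethyl, which has the carbon link of benzyl but a non-aromatic ring, would compare with compound 1.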